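A few compounds are considered here, and "the series" means these few. Any claim that something is new, unique, unknown or untested is made for them only; others in the source may bear on it.

Measured compounds:
compound 1 `COc1ccc(S(=O)(=O)NCCCN2CCN(c3cccc(C(F)(F)F)c3)CC2)cc1`, 89 nM 
compound 2 `COc1ccc(S(=O)(=O)NCCCN2CCN(c3ccc([N+](=O)[O-])cc3)CC2)cc1`, a limit of > 10000 nM 

Among the measured compounds shown here, in an assay on CHO cells for displacement of a labelled ligand from 5-hydroxytryptamine receptor 7 (Homo sapiens) (on this read-out higher numbers stand for weaker inhibition and lower numbers for stronger inhibition), compound 1 gives 89 nM, the only number obtained in this assay among the two compounds made. For compound 2 this assay returns only a limit, > 10000 nM, and no number. For the measured compounds named here, the one measured step, an at least 110-fold higher number from compound 1 to compound 2 (2.05 log units; beyond the scatter), reaches the limit described in the limit of > 10000 nM in this assay, at which 1 of the 2 values shown sits.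

Compound 3 `COc1ccc(S(=O)(=O)NC(C)CCN2CCN(c3cccc(C(F)(F)F)c3)CC2)cc1` differs from compound 1 by methyl in place of hydrogen on a saturated chain carbon bound to a saturated chain carbon and a sulfonamide nitrogen. Going by the values given here, the measured step exchanges the aryl group on the ring nitrogen and leaves the chain untouched, so it does not bear on the change to compound 3; there is no measured step on the chain at all. With nothing to point either way, compound 3 is expected to stay close to compound 1, a step of a 1.3-fold higher number from compound 1 to compound 3 (0.13 log units; within the scatter) that falls within the scatter. The estimate for compound 3 is therefore 120 nM, with a range from 35 nM to 450 nM.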

Compound 3, half-maximal inhibitory concentration: 107 nM
Estimate against measurement, compound 3: 1.1-fold (0.05 log units) above, and the stated range covers the measured number.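

In this assay, methyl in place of hydrogen on a saturated chain carbon bound to a saturated chain carbon and a sulfonamide nitrogen gives a 1.2-fold higher number from compound 1 to compound 3 (0.08 log units; within the scatter), so compound 1 and compound 3 stand within the scatter of each other. Among the compounds shown here, this is the only measured step on the chain, and it shows that this carbon accepts a methyl while the read-out stays in the same range, in contrast to the earlier step on the aryl group at the ring nitrogen, an at least 110-fold higher number from compound 1 to compound 2 (2.05 log units; beyond the scatter), which ends at a limit of the assay and not at a number. Nothing measured here gives a reason why the methyl is tolerated at this carbon.

The compounds shown leave open whether a larger group on the same carbon, such as an ethyl or a phenyl, or a hydroxyl group there, would keep the read-out in this range. They also leave open how a shorter or longer chain would fare, and whether a 3-nitrophenyl or a 4-(trifluoromethyl)phenyl on the ring nitrogen would separate the effect of the group from that of where it sits.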